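Trimming a carbamate back to a hydroxymethyl group

The source may hold more compounds than are shown below. What is called first, only, known or untested is meant among the compounds shown, and "the series" means these compounds.

Measured so far:
compound 1 `CCCC[S+]([O-])c1sc2nc(-c3nccs3)cc(-c3cccc(CO)c3)c2c1N`: 4.3 nM
compound 2 `CCCC[S+]([O-])c1sc2nc(-c3nccs3)cc(-c3nccs3)c2c1N`: 1.8 nM
compound 3 `CCCC[S+]([O-])c1sc2nc(-c3nccs3)cc(-c3ccc(COC(=O)NCC)cc3)c2c1N`: 3.4 nM

In an assay for inhibition of 15-hydroxyprostaglandin dehydrogenase [NAD(+)] (Homo sapiens), read by fluorescence, with a stated time of 15 min, in the presence of a further agent that is not named here (a higher number here means a weaker inhibitor, a lower number a stronger inhibitor), compound 3 sits second highest of the three numbers; its gaps to compound 1 and to compound 2 both lie within the scatter. Among the compounds with values here, the one step in this set, a 2.4-fold lower number from compound 1 to compound 2 (0.38 log units; beyond the scatter), exchanges the whole aryl group and does not touch the change in question. Compound 4 `CCCC[S+]([O-])c1sc2nc(-c3nccs3)cc(-c3ccc(CO)cc3)c2c1N` differs from compound 3 by hydrogen in place of ethylcarbamoyl on an oxygen on a saturated carbon. Within the data shown here, no measured step covers this; the nearest guide is that compound 1, also carrying a hydroxymethyl group, and compound 3 are within the scatter of each other. For compound 4 the expected step is therefore a 1.0-fold higher number from compound 3 to compound 4 (0.01 log units; within the scatter). Compound 4 is estimated at 3.5 nM, between 1.5 nM and 8 nM.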

Compound 4, half-maximal inhibitory concentration: 2.5 nM
For compound 4 the middle estimate is 1.4-fold (0.15 log units) above the measured one, within the range that was stated.
By their numbers in this assay, from the lowest: compounds 2, 4, 3 and 1 (each within the scatter of the next, the first and the last beyond it).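

In this assay, cutting the ethylcarbamoyl group back to leave a free hydroxymethyl group gives a 1.4-fold lower number from compound 3 to compound 4 (0.13 log units; within the scatter), so these five heavy atoms can go without a change that stands clear of the scatter. Both aryl comparisons also stay within the scatter: 4-(hydroxymethyl)phenyl gives a 1.7-fold lower number from compound 1 to compound 4 (0.24 log units; within the scatter) against 3-(hydroxymethyl)phenyl and a 1.4-fold higher number from compound 2 to compound 4 (0.14 log units; within the scatter) against 1,3-thiazol-2-yl. Nothing available offers an explanation for these results.

From the compounds shown here alone, whether an amine or a carboxylic acid could replace the hydroxymethyl group with a similar result remains open.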